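The source may hold more compounds than are shown below. What is called first, only, known or untested is meant among the compounds shown, and "the series" means these compounds.

Measured compounds in a toxicity assay on HepG2 2.2.15 cells (Homo sapiens) for cytotoxicity, read by CCK-8 assay, with a stated time of 72 h; a higher number here means that more compound is tolerated, a lower number that less compound is tolerated:

- compound 1 `O=C(CCn1cnc2cc(-c3noc(CCC4CCCCC4)n3)ccc21)N1CCCC1` — a limit only, > 20000 nM
- compound 2 `O=C(CCn1cnc2cc(-c3noc(CCc4ccccc4)n3)ccc21)N1CCCC1` — a limit only, > 20000 nM
- compound 3 `O=C(CCn1cnc2cc(-c3noc(CCC4CCCC4)n3)ccc21)N1CCOCC1` — a limit only, > 20000 nM

Compound 3 stands at the limit of this assay, as the values above show; no number within range is available for it. The same holds for compound 1 and for compound 2, so that every value in this assay sits at the limit (the limit of > 20000 nM in this assay, at which 3 of the 3 values shown sit).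

Going by the values given here, the only step between measured compounds, a step that the two limits leave unreadable from compound 1 to compound 2, cannot be read in size, since both ends are limits. It concerns the chain on the shared core, not the amide end, and so says little about the change now in question.

Compound 4 `O=C(CCn1cnc2cc(-c3noc(CCC4CCCC4)n3)ccc21)NC1CCCC1` differs from compound 3 at the amide: cyclopentylamino in place of morpholin-4-yl on a carbonyl carbon. Among the compounds with values here, no measured step in this assay bears on this position, and no step has been read as a number at all.

Given that compound 3 sits at the limit, compound 4 is expected to remain at or near the limit as well, with an expected step that the limit leaves unreadable from compound 3 to compound 4, that is none beyond the scatter. The estimate for compound 4 in this assay is 30000 nM, with a range from 15000 nM to 100000 nM.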

Compound 4, half-maximal cytotoxic concentration: > 20000 nM
Compound 4 was reported as a limit; the forecaster's own chance of this, stated with the estimate: 85%; the middle value is on the limit's open side.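

In this assay compound 3 and compound 4 are both reported only as limits, so no new step can be read across the change at the amide. The compounds shown leave open at what concentration any of them becomes cytotoxic, and whether changes at the amide or on the chain shift that concentration at all.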